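Toward a Methoxypyridinyl Variant of a Butylamino Core

The compounds below may be only part of what the source reports. "The series", "measured", "known", "first", "only" and "open" are said of these compounds alone.

Compound 1 `CCCCNc1nc(N)nc2ccn(CC(=O)NC)c12`: > 25 uM
Compound 2 `CCCCNc1nc(N)nc2ccn(Cc3ccncc3)c12`: > 25 uM

In an assay on HEK293 cells for agonist activity at Toll-like receptor 8 (Homo sapiens), read by a luciferase reporter, with a stated time of 6 h (on this read-out lower numbers stand for an effect already at smaller amounts and higher numbers for an effect only at larger amounts of compound), compound 1 gives no number, only a limit of the assay, > 25 uM. Compound 2 likewise reaches only a limit of the assay, > 25 uM. Compound 2 therefore stands at the limit of > 25 uM in this assay, at which 2 of the 2 values shown sit, and nothing finer is known of it. Among the measured compounds shown here, the one measured step, a step that the two limits leave unreadable from compound 1 to compound 2, is unreadable, since both of its ends are limits; its size cannot be told.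

Compound 3 `CCCCNc1nc(N)nc2ccn(Cc3ncccc3OC)c12` is not yet measured. It differs from compound 2 by 3-methoxypyridin-2-yl in place of pyridin-4-yl on a saturated chain carbon bound to an aromatic nitrogen. For the measured compounds named here, no measured step bears readably on this change, so the author has no size to expect beyond the scatter and no direction to name. The author expects compound 3 to remain at the same limit, an expected step of a number no higher from compound 2 to compound 3 (the limit leaves the size open). The estimate for compound 3 in this assay is 25 uM, ranging from 8 uM to 80 uM.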

Compound 3, minimum effective concentration: 0.59 uM
Compound 3: the middle estimate sits 42-fold (1.63 log units) above what was measured; the whole stated range lies above it.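

Among the compounds shown here, changing the group on a saturated chain carbon bound to an aromatic nitrogen to 3-methoxypyridin-2-yl gives the shared core a readable number in this assay for the first time, so this place can govern the result: the change from pyridin-4-yl is an at least 42-fold lower number from compound 2 to compound 3 (1.62 log units; beyond the scatter) and sets a floor on the step, not its size. Against methylcarbamoyl, the same group gives an at least 42-fold lower number from compound 1 to compound 3 (1.62 log units; beyond the scatter), again as a floor. The step between compound 1 and compound 2 cannot be read, and both remain at a limit of the assay: the limit of > 25 uM in this assay, at which 2 of the 3 values shown sit.

On these data alone, how much of the gain belongs to the methoxy group and how much to the pyridin-2-yl attachment stays open. So does what an ethoxy group or a 3-methoxyphenyl ring would give at this place.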